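Isopropyl in Place of Diethylamino in a Flat Series

The source may hold more compounds than are shown below. What is called first, only, known or untested is meant among the compounds shown, and "the series" means these compounds.

In a functional assay on A-375 cells (Homo sapiens) for antiproliferative activity, read by trypan blue exclusion and crystal violet staining, with a stated time of 72 h (on this read-out lower numbers stand for stronger inhibition and higher numbers for weaker inhibition), compound 3 (`CCCC(=O)NC(c1ccc(N(CC)CC)cc1)c1cc(Cl)c2cccnc2c1O`) gives 130 nM and stands level with compound 2 (`CCCC(=O)NC(c1ccccc1)c1cc(Cl)c2cccnc2c1O`) at 130 nM and within the scatter of compound 1 (`CCCC(=O)NC(c1ccc(Cl)cc1)c1cc(Cl)c2cccnc2c1O`) at 120 nM on the same read-out. Compound 4 (`CCCC(=O)NC(c1ccc(C(C)C)cc1)c1cc(Cl)c2cccnc2c1O`) carries isopropyl in place of diethylamino on an aromatic carbon, para to a large group (isopropyl in place of diethylamino on an aromatic carbon). Three swaps at that carbon bear on it, and a 1.1-fold higher number from compound 1 to compound 2 (0.03 log units; within the scatter) and a 1.1-fold higher number from compound 1 to compound 3 (0.03 log units; within the scatter) and no change at the digits printed from compound 2 to compound 3 (within the scatter) all lie within the scatter. No step beyond the scatter is therefore expected, so the expected step in this assay is no change at the digits printed from compound 3 to compound 4 (within the scatter) with no direction favoured. Compound 4 is estimated at 130 nM with 65 nM to 270 nM as the expected range.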

Compound 4, half-maximal inhibitory concentration: 120 nM
Compound 4: middle estimate off by 1.1-fold (0.03 log units), on the high side; the measured number falls inside the stated range.
By their numbers in this assay, from the lowest: compounds 1, 4, 2 and 3 (each within the scatter of the next).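

In this assay isopropyl on this aromatic carbon gives a 1.1-fold lower number from compound 3 to compound 4 (0.03 log units; within the scatter) and a 1.1-fold lower number from compound 2 to compound 4 (0.03 log units; within the scatter) and no change at the digits printed from compound 1 to compound 4 (within the scatter) on the same read-out. This adds a group of carbon only to the flat set, so the hydrogen-bond acceptor counted in diethylamino is not needed here to hold the number level. No measurement offered here explains this flatness. Going by these compounds, how a carboxylic acid or a primary amine on this carbon would read stays open. So does whether a longer chain in place of the butyryl chain on the amide would stay as flat.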